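The source may hold more compounds than are shown below. What is called first, only, known or untested is meant among the compounds shown, and "the series" means these compounds.

Compound 2 `N#CC1=C(N)Oc2c(c3nc4ccccc4nc3c3ccccc23)C12C(=O)N(Cc1cnnn1-c1ccc(F)cc1)c1ccccc12` belongs to a small set tested in a functional assay on HCT-116 cells (Homo sapiens) for antiproliferative activity, read by MTT assay, with a stated time of 48 h; on this read-out higher numbers stand for weaker inhibition and lower numbers for stronger inhibition. In this assay compound 2 gives > 50000 nM, and this figure is a limit of the assay rather than a number. Compound 1 `Cc1cccc(-n2nncc2CN2C(=O)C3(C(C#N)=C(N)Oc4c3c3nc5ccccc5nc3c3ccccc43)c3ccccc32)c1` differs from compound 2 only in the group carried on the aromatic nitrogen. In this assay compound 1 gives > 50000 nM, which is likewise a limit and not a number. The step that the two limits leave unreadable from compound 1 to compound 2 can therefore not be read, and the two values show no more than the limit of > 50000 nM in this assay, at which 2 of the 2 values shown sit.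

Compound 3 `N#CC1=C(N)Oc2c(c3nc4ccccc4nc3c3ccccc23)C12C(=O)N(Cc1cnnn1-c1ccc(Cl)cc1)c1ccccc12` arises from compound 2 through (chloro in place of fluoro on an aromatic carbon). For the measured compounds named here, no measured step bears on this change, because the single step known, a step that the two limits leave unreadable from compound 1 to compound 2, is unreadable. The change itself is small, so the step this estimate means, a step that the limit leaves unreadable from compound 2 to compound 3, is expected to stay within the usual scatter. Compound 3 is therefore expected to give 70000 nM in this assay, within a range from 25000 nM to 250000 nM, most probably again reported only as a limit.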

Compound 3, half-maximal inhibitory concentration: > 50000 nM
Compound 3: no number, only a limit; the forecaster's own chance of this, stated with the estimate: 80%; the middle value does not contradict the limit.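

In this assay compound 3 gives > 50000 nM as a limit of the assay and not a number. For the compounds shown here, no step among compound 1, compound 2 and compound 3 can therefore be read, and all three stop at the same limit: the limit of > 50000 nM in this assay, at which 3 of the 3 values shown sit. On these data alone, what stays open is how strongly these compounds act on the cells, and whether the group on the aromatic nitrogen changes that.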